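Swapping cyclohexyl for allyl on a thiourea nitrogen

The source may hold more compounds than are shown below. What is called first, only, known or untested is meant among the compounds shown, and "the series" means these compounds.

Of the compounds shown here, three have so far been tested in a functional assay on the whole organism with Rattus norvegicus as the target, at a dose of 100 mg/kg; on this read-out higher numbers stand for more inhibition at the one dose given (going by the name of the read-out) and lower numbers for less inhibition. Compound 1 `CC/N=C(/NC#N)NCCCn1nc(-c2ccccc2)cc(C)c1=O` gives 23.5% in this assay. Compound 2 `O=c1ccc(-c2ccccc2)nn1CCCCNC(=S)NC1CCCCC1` gives 18.1% in this assay. Compound 3 `C/N=C(\S)NCCn1nc(C)ccc1=O` gives 6% in this assay. Among these three numbers compound 2 holds the second highest place. Its gap to compound 1 lies within the usual scatter of repeated measurements, so no order between these two can be claimed. Its gap to compound 3 lies beyond the scatter, so compound 2 shows more inhibition than compound 3.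

Compound 4 `C=CCNC(=S)NCCCCn1nc(-c2ccccc2)ccc1=O` has not yet been measured in this assay. It differs from compound 2 in one place: allyl in place of cyclohexyl on an amide-type nitrogen. Going by the values given here, no pair of measured compounds differing only in this way is available, so the size of this change has not been observed directly. Since compound 2 gives 18.1% and all three measured numbers sit in a low range, the step from compound 2 to compound 4 is expected to stay within the scatter, as a number 3.1 percentage points lower from compound 2 to compound 4 (within the scatter). Compound 4 is therefore estimated to give 15% in this assay, with a range from 3% to 30%.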

Compound 4, a percentage reported as inhibition, in the whole organism at one dose (the size of the read-out at that dose, not a potency): 27.1%
For compound 4 the middle estimate is 12.1 percentage points below the measured one; the measured number falls inside the stated range.
By their numbers in this assay, from the lowest: compound 3; then compounds 2, 1 and 4 (each within the scatter of the next).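

In this assay, putting allyl in place of cyclohexyl on the amide-type nitrogen gives a number 9 percentage points higher from compound 2 to compound 4 (within the scatter), so this pair cannot be told apart. Going by these compounds alone, this is the first direct reading of any single change, and it shows that at this position, in this pair, the six-membered carbon ring can give way to an open three-carbon group with a double bond without a change that stands clear of the scatter. No measurement here explains why the two compounds read alike, and one pair cannot show whether the same swap would behave this way on another core.

From the compounds shown here alone, what remains open is whether any group on this nitrogen can move the number beyond the scatter: a small methyl, a flat phenyl ring or a longer chain such as hexyl might each answer that in a different way. Going by these compounds, a read-out at one dose also leaves open how compound 2 and compound 4 would compare at other doses, so their relative potency remains unknown.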